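Triazolyl aryl swap on the spirooxindole series: compound 3

The compounds below may be only part of what the source reports. "The series", "measured", "known", "first", "only" and "open" are said of these compounds alone.

Two members of the series have been measured in a functional assay on MCF7 cells (Homo sapiens) for antiproliferative activity, read by MTT assay, with a stated time of 48 h; on this read-out higher numbers stand for weaker inhibition and lower numbers for stronger inhibition. Compound 1 `N#CC1=C(N)Oc2c(c3nc4ccccc4nc3c3ccccc23)C12C(=O)N(Cc1cnnn1-c1ccc(F)c(Cl)c1)c1ccccc12` gives > 50000 nM, which is a limit of the assay rather than a number. Compound 2 `N#CC1=C(N)Oc2c(N)cc3nc4ccccc4nc3c2C12C(=O)N(Cc1cnnn1-c1cccc(Br)c1)c1ccccc12` gives > 50000 nM, again a limit and not a number. Going by the values given here, compound 2 therefore stands at the weak end of what this assay resolves, together with the only other value shown: the limit of > 50000 nM in this assay, at which 2 of the 2 values shown sit. Among the compounds with values here, no step between two measured compounds is available for this series.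

Compound 3 `N#CC1=C(N)Oc2c(N)cc3nc4ccccc4nc3c2C12C(=O)N(Cc1cnnn1-c1cc(Cl)ccc1Cl)c1ccccc12` differs from compound 2 in one place: 2,5-dichlorophenyl in place of 3-bromophenyl on an aromatic nitrogen. No measurement links this change to a shift in potency. The step that the limit leaves unreadable from compound 2 to compound 3 is expected to be none beyond the scatter, because compound 2 already sits at the limit (the limit of > 50000 nM in this assay, at which 2 of the 2 values shown sit). Compound 3 is expected to give about 60000 nM in this assay, with a range from 20000 nM to 200000 nM, and most likely to be reported again only as a limit.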

Compound 3, half-maximal inhibitory concentration: 33200 nM
For compound 3 the middle estimate is 1.8-fold (0.26 log units) above the measured one; the measured number falls inside the stated range.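

In this assay, going by these compounds alone, compound 3 gives 33200 nM, the first value that is a number and not a limit, so this aromatic nitrogen can carry an aryl group with a readable result on the shared core. Setting 2,5-dichlorophenyl in place of 3-bromophenyl gives an at least 1.5-fold lower number from compound 2 to compound 3 (0.17 log units; that floor lies within the scatter), so the data do not establish a real change in potency. The true size of this step stays unknown because compound 2 is reported only as a limit: the limit of > 50000 nM in this assay, at which 2 of the 3 values shown sit.

As far as these compounds go, it remains open whether the two chlorines of compound 3 matter individually, or whether their placement on the ring does. From the compounds shown here alone, how a phenyl group carrying an amine or a carboxylic acid would read at this position also remains open.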